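Cyanophenyl in Place of Methylphenyl on the Shared Core

The compounds below may be only part of what the source reports. "The series", "measured", "known", "first", "only" and "open" are said of these compounds alone.

Compound 1 `Cc1ccccc1Cn1cc(COc2ccc3c(=O)ccoc3c2)nn1` carries a 2-methylphenyl group on a saturated chain carbon bound to an aromatic nitrogen. In a functional assay on A549 cells (Homo sapiens) for cytotoxicity, read by MTT assay, with a stated time of 48 h (on this read-out lower numbers stand for stronger inhibition and higher numbers for weaker inhibition), compound 1 reaches only the limit, > 100000 nM, so no number stands for it. Compound 3 `CC(C)(C)c1ccc(Cn2cc(COc3ccc4c(=O)ccoc4c3)nn2)cc1` also sits at the limit in this assay, > 100000 nM. Among the compounds with values here, compound 2 `O=c1ccoc2cc(OCc3cn(Cc4cccc([N+](=O)[O-])c4)nn3)ccc12` is the one compound with a number in this assay, 9450 nM. Within the data shown here, the only measured step is an at least 10-fold lower number from compound 1 to compound 2 (1.02 log units; beyond the scatter), and since two of the three values sit at the limit (the limit of > 100000 nM in this assay, at which 2 of the 3 values shown sit), that step itself is only a floor. Compound 4 `N#Cc1ccc(Cn2cc(COc3ccc4c(=O)ccoc4c3)nn2)cc1` differs from compound 1 by 4-cyanophenyl in place of 2-methylphenyl on a saturated chain carbon bound to an aromatic nitrogen. The step to compound 2 is the one that bears on this change, and because the 3-nitrophenyl replacement gave an at least 10-fold lower number from compound 1 to compound 2 (1.02 log units; beyond the scatter) a step downward beyond the scatter is expected here too, though a smaller one, since only one replacement has left the limit. Compound 4 is therefore estimated at 30000 nM, with a range from 8000 nM to 100000 nM. The expected step is an at least 3.3-fold lower number from compound 1 to compound 4 (0.52 log units; beyond the scatter).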

Compound 4, half-maximal inhibitory concentration: > 100000 nM
Compound 4: a limit, no number; the forecaster's own chance of this, stated with the estimate: 45%; at least 3.3-fold (0.52 log units) between middle value and limit.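

Within the data shown here, compound 4 shows that a second replacement on a saturated chain carbon bound to an aromatic nitrogen, this time 4-cyanophenyl, does not by itself bring the shared core off the limit in this assay, so the 3-nitrophenyl group of compound 2 remains the only one here with a number. Exchanging 3-nitrophenyl for 4-cyanophenyl gives an at least 10-fold higher number from compound 2 to compound 4 (1.02 log units; beyond the scatter), which marks this position as sensitive to the choice between these two groups, although the result for compound 4 is a limit and the step is only a floor. The steps from compound 1 and from compound 3 to compound 4 cannot be read, and the limit now dominates the series: the limit of > 100000 nM in this assay, at which 3 of the 4 values shown sit.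

The compounds shown leave open whether the number for compound 2 goes with the nitro group or with its place on the ring. How a benzyl group carrying an amine or a carboxylic acid would read in this assay is open as well.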